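Compound 3 to compound 4: a new group on the amide

The compounds below may be only part of what the source reports. "The series", "measured", "known", "first", "only" and "open" are said of these compounds alone.

Measured so far in an ADME assay on microsomes from liver (Mus musculus, strain CD-1) for metabolic stability, read by LC-MS, tested at 2 uM; a lower number here means that the compound disappears faster, a higher number that the compound lasts longer
Compound 1 `CN(C)C(=O)c1ccncc1Nc1cc(-c2ccc3ccn(C)c3c2)c2nccnc2c1` gives 0.35 h
Compound 2 `Cn1ccc2ccc(-c3cc(Nc4cnccc4C(=O)NC4CCNC(=O)C4)cc4nccnc34)cc21` gives > 1 h as a limit of the assay
Compound 3 `CN1CCC(NC(=O)c2ccncc2Nc2cc(-c3ccc4ccn(C)c4c3)c3nccnc3c2)CC1=O` gives 0.717 h

Compound 3 gives 0.717 h as the higher of the two exact numbers, and compound 1 gives 0.35 h as the lower. Compound 2 gives > 1 h and that is a limit of the assay, not a number.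

Compound 4 `CC(=O)N1CC(NC(=O)c2ccncc2Nc2cc(-c3ccc4ccn(C)c4c3)c3nccnc3c2)C1` carries 1-acetylazetidin-3-yl in place of 1-methyl-2-oxopiperidin-4-yl on the amide-type nitrogen, and 1-acetylazetidin-3-yl in place of 1-methyl-2-oxopiperidin-4-yl on an amide-type nitrogen gives the counts for this swap. For the measured compounds named here, three measured steps concern this same part of the molecule. Replacing dimethylamino on the carbonyl carbon gave an at least 2.8-fold higher number from compound 1 to compound 2 (0.45 log units; beyond the scatter) and a 2.0-fold higher number from compound 1 to compound 3 (0.31 log units; beyond the scatter) and both lie beyond the scatter. Putting methyl in place of hydrogen on the amide-type nitrogen in the ring gave an at least 1.3-fold lower number from compound 2 to compound 3 (0.14 log units; that floor lies within the scatter) and that floor lies within the scatter. None of these compounds carries 1-acetylazetidin-3-yl, so the three steps give no direction for this swap. The expected step is therefore a 1.1-fold higher number from compound 3 to compound 4 (0.05 log units; within the scatter) and this estimate stays within the scatter. The estimate for compound 4 is 0.8 h with an expected range from 0.4 h to 1.5 h as the likely span in this assay here.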

Compound 4, half-life: 0.817 h
Compound 4: the middle estimate sits 1.0-fold (0.01 log units) below what was measured; measured number inside the range.
By their numbers in this assay, from the lowest: compound 1; then compounds 3 and 4 (each within the scatter of the next). At a limit, above all of these: compound 2.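

In this assay, the four-membered ring of 1-acetylazetidin-3-yl on the amide-type nitrogen serves about as well as the six-membered ring of 1-methyl-2-oxopiperidin-4-yl, with a 1.1-fold higher number from compound 3 to compound 4 (0.06 log units; within the scatter). The carbonyl also sits outside the ring in the new group and inside it in the old one, so this position tolerates a change in both ring size and carbonyl placement with no readable shift in half-life. The gain over dimethylamino on the carbonyl carbon therefore no longer rests on the 2-oxopiperidine ring alone, with a 2.3-fold higher number from compound 1 to compound 4 (0.37 log units; beyond the scatter); compound 2 gives > 1 h, which is a limit of the assay and not a number, so the step of an at least 1.2-fold lower number from compound 2 to compound 4 (0.08 log units; that floor lies within the scatter) is only a floor and does not settle how the two compare: the limit of > 1 h in this assay, at which 1 of the 4 values shown sits.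

Ring size and the acetyl group changed together here, so the compounds shown do not separate them; 1-acetylpiperidin-4-yl or 1-methylazetidin-3-yl on the same nitrogen would pull the two apart. On these data alone, how a free amine or a carboxylic acid at this position would behave in this assay also remains open.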